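Swapping the amide arm for an aryl group on the triazole

The source may report more compounds than this note shows. Statements on the series, on what has been measured and on what is new or still open speak of the compounds shown alone.

Of the compounds shown here, three sharing one core have been tested in a functional assay on MCF7 cells (Homo sapiens) for inhibition, read by MTT assay, with a stated time of 24 h; on this read-out lower numbers stand for stronger inhibition and higher numbers for weaker inhibition. Compound 1 `CCOC(=O)C1=Cc2ccccc2OC1(OCc1cn(CC(=O)Nc2ccc(C)cc2)nn1)C(F)(F)F` reaches only the limit > 150000 nM, so no number is known for it. Compound 3 `CCOC(=O)C1=Cc2ccccc2OC1(OCc1cc(-c2ccc([N+](=O)[O-])cc2)no1)C(F)(F)F` likewise stops at the limit > 150000 nM. Among the compounds with values here, compound 2 `CCOC(=O)C1=Cc2ccccc2OC1(OCc1cn(CC(=O)Nc2ccccc2F)nn1)C(F)(F)F` is the one compound with a number, 42100 nM, and so the only firm point to build on. Within the data shown here, the single measured step, an at least 3.5-fold lower number from compound 1 to compound 2 (0.55 log units; beyond the scatter), shows that changing the group on the amide-type nitrogen shifts the number beyond the scatter.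

Compound 4 `CCOC(=O)C1=Cc2ccccc2OC1(OCc1cn(-c2ccc(F)c(Cl)c2)nn1)C(F)(F)F` differs from compound 2 by 3-chloro-4-fluorophenyl in place of ((2-fluorophenyl)carbamoyl)methyl on an aromatic nitrogen. This change is broader than the measured step, since the whole amide-bearing arm leaves and an aryl group takes its place on the ring nitrogen, so that step gives only a rough guide. Two of the three values sit at the limit of > 150000 nM in this assay, at which 2 of the 3 values shown sit, which points to weak inhibition across this small set. Compound 4 is therefore expected to give about 100000 nM, with a likely range from 30000 nM to 150000 nM. The expected step of a 2.4-fold higher number from compound 2 to compound 4 (0.38 log units; beyond the scatter) would mean weaker inhibition, with a real chance that only a limit is recorded.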

Compound 4, half-maximal inhibitory concentration: 25300 nM
Estimate against measurement, compound 4: 4.0-fold (0.60 log units) above; the whole stated range lies above it.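

At this position, the amide-bearing arm is not required for a measurable number in this assay: a 3-chloro-4-fluorophenyl group set directly on the aromatic nitrogen of the five-membered ring also gives one. Replacing ((2-fluorophenyl)carbamoyl)methyl with this group gives a 1.7-fold lower number from compound 2 to compound 4 (0.22 log units; within the scatter), so the two compounds stand level despite the loss of the amide. Replacing ((4-methylphenyl)carbamoyl)methyl gives an at least 5.9-fold lower number from compound 1 to compound 4 (0.77 log units; beyond the scatter), which is only a bound and not an exact size, since compound 1 sits at a limit: the limit of > 150000 nM in this assay, at which 2 of the 4 values shown sit.

Going by these compounds, it remains open how much the chlorine and fluorine on the new ring contribute, which a plain phenyl group on this nitrogen would help to test. Also open, on these data alone, is how a benzyl group, with one carbon between the nitrogen and the ring, or a ring carrying an amine or a carboxylic acid, would read here.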